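A few compounds are considered here, and "the series" means these few. Any claim that something is new, unique, unknown or untested is made for them only; others in the source may bear on it.

For the measured compounds named here, in an assay on HEK293 cells for activation of Kir3.1/Kir3.2 (Homo sapiens), read by thallium flux (on this read-out lower numbers stand for smaller maximal responses and higher numbers for larger maximal responses), compound 2 `Cc1cc(NC(=O)Cn2nnc(-c3cccc(Cl)c3)n2)n(C2CCCCC2)n1` gives 89%, the higher of the two numbers measured so far. Compound 1 `Cc1cc(NC(=O)Cn2nnc(-c3ccccc3)n2)n(C2CCC(F)(F)CC2)n1` gives 68%, a gap beyond the usual scatter. Compound 3 `Cc1cc(NC(=O)Cn2nnc(C3CC3)n2)n(C2CCCCC2)n1` differs from compound 2 by one change: cyclopropyl in place of 3-chlorophenyl on an aromatic carbon. Going by the values given here, no measured pair shows this change, so there is no measured step to lean on. A smaller group in this position is expected to lower the maximal response, though without evidence from this series the size is uncertain. Compound 3 is expected to reach 65%, with a likely range from 40% to 90%. The expected step of a number 24 percentage points lower from compound 2 to compound 3 (beyond the scatter) is therefore downward, of moderate size.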

Compound 3, largest response reached (Emax), in percent of the reference or control that the assay uses: > 68%
Compound 3: no number, only a limit; the forecaster's own chance of this, stated with the estimate: 5%; at least 3 percentage points between middle value and limit.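

In this assay compound 3 gives > 68%, which is a limit and not a number, so the step from compound 2 to compound 3 cannot be read. Going by these compounds, whether cyclopropyl gives a smaller, similar or larger maximal response than 3-chlorophenyl stays open.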